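The compounds below may be only part of what the source reports. "The series", "measured", "known", "first", "only" and "open" are said of these compounds alone.

Measured in a functional assay on DU-145 cells (Homo sapiens) for cytotoxicity, read by trypan blue exclusion, with a stated time of 96 h; on this read-out lower numbers stand for stronger inhibition and higher numbers for weaker inhibition:
- compound 1 `COc1cc(OC)c(/C=C/S(=O)(=O)Nc2ccc(F)c(N)c2)c(OC)c1` gives 10000 nM
- compound 2 `COc1cc(OC)c(/C=C/S(=O)(=O)Nc2ccc(OC)c(O)c2)c(OC)c1` gives 30 nM
- compound 3 `COc1ccc(NS(=O)(=O)/C=C/c2c(OC)cc(OCCCC(=O)O)cc2OC)cc1O` gives 10000 nM

Compound 2 holds the lowest of these three numbers. Compound 4 `COC(=O)CNc1cc(NS(=O)(=O)/C=C/c2c(OC)cc(OC)cc2OC)ccc1OC` is not yet measured. It differs from compound 2 by ((methoxycarbonyl)methyl)amino in place of hydroxy on an aromatic carbon, with ((methoxycarbonyl)methyl)amino in place of hydroxy, ortho to a methoxy group.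

Among the measured compounds shown here, two measured steps bear on this. Change on the group on the sulfonamide nitrogen gave a 330-fold lower number from compound 1 to compound 2 (2.52 log units; beyond the scatter), and added bulk elsewhere on compound 2 gave a 330-fold higher number from compound 2 to compound 3 (2.52 log units; beyond the scatter). Neither step makes this exact change, so a rise is expected, but a smaller one than these.

The expected step is a 5.0-fold higher number from compound 2 to compound 4 (0.70 log units; beyond the scatter).

Compound 4 is estimated at 150 nM, with an expected range of 20 nM to 2000 nM.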

Compound 4, half-maximal inhibitory concentration: 350 nM
For compound 4 the middle estimate is 2.3-fold (0.37 log units) below the measured one; low and high end bracket the measured number.
By their numbers in this assay, from the lowest: compound 2; then compound 4; then compounds 1 and 3 (each within the scatter of the next).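

Of the steps shown, only this one changes the hydroxy position alone: in this assay, ((methoxycarbonyl)methyl)amino in place of hydroxy, ortho to a methoxy group, gives a 12-fold higher number from compound 2 to compound 4 (1.07 log units; beyond the scatter). The position therefore accepts a much larger group, with 6 heavy atoms in place of 1, at a real cost, and compound 4 still reaches 350 nM. No measurement is available to explain this step. Going by these compounds, it remains open whether the loss belongs to the nitrogen or to the ester chain; a plain amino group or the carboxylic acid at this position would separate the two.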